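Ethyl to methyl on the ring amine in the series

The compounds below may be only part of what the source reports. "The series", "measured", "known", "first", "only" and "open" are said of these compounds alone.

Of the compounds shown here, two of the shared core have been measured. Compound 1 `CCN1C/C(=C\c2ccc(OC)cc2)C2=NN(C(N)=S)C(c3ccc(OC)cc3)C2C1` gives 88.2% in a physicochemical assay for inhibition, read by colorimetric assay, tested at 1 mg/mL; on this read-out higher numbers stand for more inhibition at the one concentration tested (going by the name of the read-out) and lower numbers for less inhibition. Compound 2 `CCN1C/C(=C\c2ccc(OC)cc2)C2=NN(c3nc(-c4ccc(Cl)cc4)cs3)C(c3ccc(OC)cc3)C2C1` gives 82.6% in this assay. Among the compounds with values here, the one step measured so far, a number 5.6 percentage points lower from compound 1 to compound 2 (within the scatter), exchanges the group on the ring nitrogen and says nothing about the chain on the amine nitrogen. On the numbers shown, compound 2 stands lowest of the two, with compound 1 as its nearest neighbour within the scatter, so neither can be called the stronger.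

Compound 3 `COc1ccc(/C=C2\CN(C)CC3C2=NN(c2nc(-c4ccc(Cl)cc4)cs2)C3c2ccc(OC)cc2)cc1` differs from compound 2 in one place: hydrogen in place of methyl on a saturated chain carbon bound to an amine nitrogen in a ring. Within the data shown here, no measured step touches this position, so there is nothing to suggest a direction. Among the measured compounds shown here, the only precedent, the exchange from compound 1 to compound 2, left the read-out within the scatter despite a much larger change than ethyl to methyl.

For compound 3 the step from compound 2 is therefore expected to be a number 2.6 percentage points lower from compound 2 to compound 3 (within the scatter), none beyond the scatter. Compound 3 is estimated to give 80% in this assay, within a range from 65% to 92%.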

Compound 3, a percentage reported as inhibition, at one concentration (the size of the read-out at that concentration, not a potency): 69.6%
For compound 3 the middle estimate is 10.4 percentage points above the measured one; the measured number falls inside the stated range.
By their numbers in this assay, from the lowest: compound 3; then compounds 2 and 1 (each within the scatter of the next).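

In this assay, the chain on the amine nitrogen in a ring is a position where a small change can move the read-out: ethyl to methyl, with one methyl replaced by hydrogen at the chain end, gives a number 13 percentage points lower from compound 2 to compound 3 (beyond the scatter). Within the data shown here, the only earlier step, a number 5.6 percentage points lower from compound 1 to compound 2 (within the scatter), exchanged a much larger group at a different place and stayed within the scatter, so the size of a change does not track the size of the step across these two pairs. No measurement available here accounts for the drop at this position.

Among these compounds, the effect rests on a single pair, so it remains open whether ethyl to methyl gives a step of similar size when the group of compound 1 is carried in place of the one shared by compound 2 and compound 3. Also open, going by these compounds, is how the read-out responds when this amine nitrogen carries a longer chain such as propyl or butyl, or a benzyl group, which would show whether the number keeps rising as the chain grows beyond ethyl.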